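Varying the aryl group on the sulfur-linked chain

A few compounds are considered here, and "the series" means these few. Any claim that something is new, unique, unknown or untested is made for them only; others in the source may bear on it.

Measured compounds:
compound 1 `Cc1cc(Nc2cc(-c3ccccc3)[nH]n2)n2nc(SCc3csc4ccccc34)nc2n1`: 2280 nM
compound 2 `Cc1cc(Nc2cc(-c3ccccc3)[nH]n2)n2nc(SCc3ccc(Cl)cc3)nc2n1`: 3950 nM
compound 3 `Cc1cc(Nc2cc(-c3ccccc3)[nH]n2)n2nc(SCc3ccc(C(F)(F)F)cc3)nc2n1`: 3520 nM

In a functional assay on MGC-803 cells (Homo sapiens) for inhibition, read by MTT assay, with a stated time of 72 h (on this read-out lower numbers stand for stronger inhibition and higher numbers for weaker inhibition), compound 3 gives 3520 nM, the second highest of the three numbers; its nearest neighbour is compound 2, and compound 1 is furthest, yet both of these steps, a 1.1-fold lower number from compound 2 to compound 3 (0.05 log units; within the scatter) and a 1.5-fold higher number from compound 1 to compound 3 (0.19 log units; within the scatter), stay within the scatter. Compound 4 `Cc1cc(Nc2cc(-c3ccccc3)[nH]n2)n2nc(SCc3ccccc3Br)nc2n1` is not yet measured. Compared with compound 3, the change is 2-bromophenyl in place of 4-(trifluoromethyl)phenyl on a saturated chain carbon bound to a sulfur. Among the measured compounds shown here, the steps that bear on this place, a 1.7-fold higher number from compound 1 to compound 2 (0.24 log units; within the scatter) and a 1.5-fold higher number from compound 1 to compound 3 (0.19 log units; within the scatter), were all within the scatter, so a change at the aryl group on the chain carbon bound to sulfur has so far moved nothing beyond it. Compound 4 is therefore expected to give about 3400 nM, with a range from 1700 nM to 7000 nM, a step of a 1.0-fold lower number from compound 3 to compound 4 (0.02 log units; within the scatter).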

Compound 4, half-maximal inhibitory concentration: 3650 nM
The estimate for compound 4 lay 1.1-fold (0.03 log units) below the measured number; measured number inside the range.
By their numbers in this assay, from the lowest: compounds 1, 3, 4 and 2 (each within the scatter of the next).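

In this assay the 2-bromophenyl group on a saturated chain carbon bound to a sulfur joins the groups already seen, with the steps of a 1.0-fold higher number from compound 3 to compound 4 (0.02 log units; within the scatter) against 4-(trifluoromethyl)phenyl, a 1.1-fold lower number from compound 2 to compound 4 (0.03 log units; within the scatter) against 4-chlorophenyl and a 1.6-fold higher number from compound 1 to compound 4 (0.20 log units; within the scatter) against 1-benzothiophen-3-yl. The substitution pattern of the ring can thus differ, as in 2-bromophenyl and the 4-substituted phenyl groups, while all four aryl groups stay within the scatter of one another. No evidence is available to explain this flat result. As far as these compounds go, whether an amine, a carboxylic acid or a longer chain at this place would move the number beyond the scatter remains open.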